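A Longer Sulfonate Side Chain and Its Expected Stability

The source may hold more compounds than are shown below. What is called first, only, known or untested is meant among the compounds shown, and "the series" means these compounds.

Compound 1, `CC1(C)C(=O)N(CCCS(=O)(=O)O)C(=O)N1Cl`, gives > 336 h in a physicochemical assay for metabolic stability, at 40 degrees C (on this read-out higher numbers stand for a longer-lived compound and lower numbers for a shorter-lived compound), a limit of the assay rather than a number.
Compound 2, `CC1(C)C(=O)N(CCS(=O)(=O)O)C(=O)N1Cl`, gives 1560 h in this assay.

The step from compound 1 to compound 2, a step that the limit leaves unreadable from compound 1 to compound 2, is sulfo in place of sulfomethyl on a saturated chain carbon, two bonds along the chain from an amide-type nitrogen in a ring. Its size cannot be read because of the limit of > 336 h in this assay, at which 1 of the 2 values shown sits. Within the data shown here, compound 2 therefore stands alone as the only number among the two results, the other being a limit.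

Compound 3, `CC1(C)C(=O)N(CCS(=O)(=O)CCCS(=O)(=O)O)C(=O)N1Cl`, differs from compound 2 by 3-sulfopropyl in place of hydroxy on a sulfonyl sulfur. Among the measured compounds shown here, no measured step bears on this change: the one step known is unreadable and concerns a different place in the molecule. With nothing to point either way, compound 3 is expected to behave much like compound 2, so the step of a 1.3-fold lower number from compound 2 to compound 3 (0.11 log units; within the scatter) is expected to lie within the usual scatter. Compound 3 is estimated at 1200 h, with a range from 400 h to 3000 h.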

Compound 3, half-life: > 168 h
Compound 3 was reported as a limit (the forecaster's own chance of this, stated with the estimate: 30%); the middle value does not contradict the limit.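

The result for compound 3 is a limit of the assay and not a number, and no new step can be read from compound 2 to compound 3 because of it: the limit of > 168 h in this assay, at which 1 of the 3 values shown sits.

The compounds shown leave open how long compound 3 actually lasts in this assay, and whether 3-sulfopropyl in place of hydroxy on a sulfonyl sulfur changes the half-life at all.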